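The source may report more compounds than this note shows. Statements on the series, on what has been measured and on what is new or still open speak of the compounds shown alone.

Measured in a functional assay on MKN-45 cells (Homo sapiens) for cytotoxicity, read by MTT assay, with a stated time of 72 h; on this read-out lower numbers stand for stronger inhibition and higher numbers for weaker inhibition: compound 1 `CN(C)CCCNc1nc(-c2ccc(NC(=O)Nc3ccc(F)cc3)cc2)nc2c(Cl)c(Cl)sc12` gives 1120 nM; compound 2 `CCN(CC)CCCNc1nc(-c2ccc(NC(=O)Nc3ccc(F)cc3)cc2)nc2c(Cl)c(Cl)sc12` gives 1700 nM.

Compound 2 has only compound 1 as a neighbour, and the two are not set apart, since the step of a 1.5-fold higher number from compound 1 to compound 2 (0.18 log units; within the scatter) stays within the scatter. Compound 3 `CCN(CC)CCNc1nc(-c2ccc(NC(=O)Nc3ccc(F)cc3)cc2)nc2c(Cl)c(Cl)sc12` differs from compound 2 by diethylamino in place of (diethylamino)methyl on a saturated chain carbon, two bonds along the chain from a nitrogen on an aromatic ring. Within the data shown here, no measured step touches this chain; the single step known concerns the amine substituent and was itself within the scatter, so it offers no direction. The step is therefore expected to be a 1.1-fold lower number from compound 2 to compound 3 (0.05 log units; within the scatter), nothing beyond the scatter. Compound 3 is estimated at 1500 nM, between 500 nM and 4500 nM.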

Compound 3, half-maximal inhibitory concentration: 1370 nM
Estimate against measurement, compound 3: 1.1-fold (0.04 log units) above; the measured number falls inside the stated range.
By their numbers in this assay, from the lowest: compounds 1, 3 and 2 (each within the scatter of the next).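

Putting 2-(diethylamino)ethyl in place of 3-(diethylamino)propyl on the shared core gives no separation in this assay (a 1.2-fold lower number from compound 2 to compound 3 (0.09 log units; within the scatter)), so the chain at this position can differ in this way without leaving the scatter. Shortening the chain and changing the end amine together, as the step between the dimethylamino and diethylamino compounds does, also sets nothing apart (a 1.2-fold higher number from compound 1 to compound 3 (0.09 log units; within the scatter)). No measurement shown bears on why. Still open, as far as these compounds go, is whether a longer chain, such as 4-(diethylamino)butyl, or a ring amine at the chain end, such as morpholine, would stand apart from these compounds.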